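The compounds below may be only part of what the source reports. "The series", "measured", "known", "first", "only" and "open" are said of these compounds alone.

Of the compounds shown here, three of one shared core have been measured in an assay on CHO cells for displacement of a labelled ligand from melanin-concentrating hormone receptor 1 (Homo sapiens), read by scintillation counting, with a stated time of 1 h; a higher number here means a weaker inhibitor, a lower number a stronger inhibitor. Compound 1 `Cc1c(C2CC2)nc2ccc(-n3ccc(OCc4ccc(Cl)cc4)cc3=O)nn12` gives 380 nM in this assay. Compound 2 `Cn1c(C2CC2)nc2ccc(-n3ccc(OCc4ccc(Cl)cc4)cc3=O)cc21` gives 35 nM. Compound 3 `Cc1nc2ccc(-n3ccc(OCc4ccc(F)cc4)cc3=O)cc2n1C` gives 77 nM. Among these three numbers compound 3 stands second highest: its nearest neighbour is compound 2, whose number is lower by a margin beyond the scatter, and its furthest is compound 1, whose number is higher by a larger margin, also beyond the scatter. Compound 2 and compound 3 differ from each other in more than one place, so their two values show only that the chloro-cyclopropyl pairing sits lower than the fluoro-methyl pairing.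

Compound 4 `Cn1c(C2CCC2)nc2ccc(-n3ccc(OCc4ccc(F)cc4)cc3=O)cc21` is the next compound in the series and has not yet been measured. It differs from compound 3 in one place: cyclobutyl in place of methyl on an aromatic carbon, on the five-membered aromatic ring with two nitrogen atoms of the fused system. For the measured compounds named here, no single-change pair already measured mirrors this replacement, so the expectation rests on the whole set. Compound 2, with a three-membered carbon ring in the same place, gives 35 nM, the lowest number of the three. On that basis compound 4 is expected to move downward from compound 3 by a modest step, a 1.9-fold lower number from compound 3 to compound 4 (0.28 log units; within the scatter), and its value in this assay is estimated at 40 nM, within a range from 12 nM to 130 nM.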

Compound 4, half-maximal inhibitory concentration: 240 nM
The estimate for compound 4 lay 6.0-fold (0.78 log units) below the measured number, and the stated range ends below it.
By their numbers in this assay, from the lowest: compound 2; then compound 3; then compounds 4 and 1 (each within the scatter of the next).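

In this assay, cyclobutyl in place of methyl on the aromatic carbon between two ring nitrogen atoms gives a 3.1-fold higher number from compound 3 to compound 4 (0.49 log units; beyond the scatter). For the compounds shown here, this is the first step at this position with the rest of the molecule held fixed, and it shows that a carbon ring here need not bring a lower number: with the fluorine-bearing side unchanged, the larger group gives a modestly higher one. The low number of compound 2, 35 nM, therefore cannot be credited to a carbon ring at this position alone, since compound 2 differs from compound 4 in more than one place, and nothing available explains the rise from compound 3 to compound 4.

The compounds shown leave open whether the number climbs steadily with the size of the group here, which an ethyl, an isopropyl or a cyclopentyl group at the same carbon would help to show. They also leave open how much of the gap between compound 2 and compound 4 belongs to cyclopropyl against cyclobutyl and how much to chlorine against fluorine on the far ring.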